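Varying the amide aryl group on a shared flavonol core

A few compounds are considered here, and "the series" means these few. Any claim that something is new, unique, unknown or untested is made for them only; others in the source may bear on it.

Compound 1 `O=C(Nc1cccc(-c2oc3cc(-c4ccc(F)cc4)ccc3c(=O)c2O)c1)c1ccccc1F` was tested in a functional assay on A549 cells (Homo sapiens) for antiproliferative activity, read by CCK-8 assay, with a stated time of 72 h (on this read-out lower numbers stand for stronger inhibition and higher numbers for weaker inhibition), where it gives 4410 nM. Two close relatives share its core and differ only in the aromatic group attached to the amide carbonyl. Compound 2 `Cc1cccc(C(=O)Nc2cccc(-c3oc4cc(-c5ccc(F)cc5)ccc4c(=O)c3O)c2)c1` gives 16500 nM, and compound 3 `COc1cc(OC)cc(C(=O)Nc2cccc(-c3oc4cc(-c5ccc(F)cc5)ccc4c(=O)c3O)c2)c1` gives 2390 nM. Among these three numbers compound 1 stands second highest: the change to compound 2 brings a 3.7-fold higher number from compound 1 to compound 2 (0.57 log units; beyond the scatter), whereas the change to compound 3 brings a 1.8-fold lower number from compound 1 to compound 3 (0.27 log units; within the scatter). Between the two relatives themselves the step is a 6.9-fold lower number from compound 2 to compound 3 (0.84 log units; beyond the scatter).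

Compound 4 `N#Cc1ccc(C(=O)Nc2cccc(-c3oc4cc(-c5ccc(F)cc5)ccc4c(=O)c3O)c2)cc1` has not yet been measured. Its difference from compound 1 is 4-cyanophenyl in place of 2-fluorophenyl on a carbonyl carbon. Within the data shown here, none of the measured steps puts a nitrile at that carbonyl, so there is no direct precedent; the measured changes at this position span from the modest loss seen in a 3.7-fold higher number from compound 1 to compound 2 (0.57 log units; beyond the scatter) to the small gain in a 1.8-fold lower number from compound 1 to compound 3 (0.27 log units; within the scatter). On that basis compound 4 is expected to stay close to compound 1, a step of a 1.0-fold higher number from compound 1 to compound 4 (0.01 log units; within the scatter) with no clear direction, giving an estimate of 4500 nM, ranging from 1500 nM to 14000 nM.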

Compound 4, half-maximal inhibitory concentration: 2360 nM
Compound 4: the middle estimate sits 1.9-fold (0.28 log units) above what was measured, within the range that was stated.
By their numbers in this assay, from the lowest: compounds 4, 3 and 1 (each within the scatter of the next); then compound 2.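

In this assay a nitrile on the aryl group at this carbonyl carbon is tolerated: 4-cyanophenyl in place of 2-fluorophenyl gives a 1.9-fold lower number from compound 1 to compound 4 (0.27 log units; within the scatter) and so makes no change that can be told from the scatter. Two very different rings, 4-cyanophenyl and 3,5-dimethoxyphenyl, also sit level, with a 1.0-fold lower number from compound 3 to compound 4 (0.01 log units; within the scatter) as their step, while 3-methylphenyl remains the outlier, as a 7.0-fold lower number from compound 2 to compound 4 (0.84 log units; beyond the scatter) shows. Nothing in hand explains why these groups behave alike.

It remains open whether the nitrile would give the same number on a different ring position, as only 4-cyanophenyl is shown. On these data alone, how this position responds to an aryl group carrying an amine or a carboxylic acid, or to a saturated ring in place of the aryl group, also remains unknown.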